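Swapping a methylphenyl amide for a nitrophenyl amide

The compounds below may be only part of what the source reports. "The series", "measured", "known", "first", "only" and "open" are said of these compounds alone.

Of the compounds shown here, three built on one shared core have been tested in a functional assay on MCF7 cells (Homo sapiens) for inhibition, read by MTT assay, with a stated time of 72 h; a lower number here means a stronger inhibitor, a higher number a weaker inhibitor. Compound 1 `O=C(Nc1ccccc1)c1ccc(/N=N\c2c[nH]c3ccccc23)cc1` gives 147000 nM. Compound 2 `Cc1cccc(NC(=O)c2ccc(/N=N\c3c[nH]c4ccccc34)cc2)c1C` gives 106000 nM. Compound 3 `Cc1ccccc1NC(=O)c1ccc(/N=N\c2c[nH]c3ccccc23)cc1` gives 73400 nM. Compound 3 holds the lowest of the three numbers, yet the step of a 2.0-fold lower number from compound 1 to compound 3 (0.30 log units; within the scatter) and the step of a 1.4-fold lower number from compound 2 to compound 3 (0.16 log units; within the scatter) both lie within the scatter, so these three compounds cannot be told apart on the figures so far. The step of a 1.4-fold lower number from compound 1 to compound 2 (0.14 log units; within the scatter) also stays within the scatter.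

Compound 4 `O=C(Nc1ccc([N+](=O)[O-])cc1)c1ccc(/N=N\c2c[nH]c3ccccc23)cc1` has not yet been measured. It differs from compound 3 in one place: 4-nitrophenyl in place of 2-methylphenyl on an amide-type nitrogen. Going by the values given here, no measured step brings in a group of this kind; the three steps known so far only add or remove methyl groups on the phenyl ring attached to the amide nitrogen, and every one of them stayed within the scatter. Because the steps of a 2.0-fold lower number from compound 1 to compound 3 (0.30 log units; within the scatter) and a 1.4-fold lower number from compound 2 to compound 3 (0.16 log units; within the scatter) were that small, no step beyond the scatter is expected here either, in either direction. Compound 4 is therefore expected to give about 80000 nM in this assay, with a range from 30000 nM to 200000 nM. This estimate implies a step of a 1.1-fold higher number from compound 3 to compound 4 (0.04 log units; within the scatter).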

Compound 4, half-maximal inhibitory concentration: 54500 nM
Beside the measured number, compound 4's estimate is 1.5-fold (0.17 log units) above it, and the stated range covers the measured number.
By their numbers in this assay, from the lowest: compounds 4, 3, 2 and 1 (each within the scatter of the next, the first and the last beyond it).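

Placing 4-nitrophenyl on the amide-type nitrogen moves beyond the methyl-substituted rings tested so far, yet in this assay it gives a 1.3-fold lower number from compound 3 to compound 4 (0.13 log units; within the scatter) and a 1.9-fold lower number from compound 2 to compound 4 (0.29 log units; within the scatter), so compound 2, compound 3 and compound 4 still cannot be told apart. Going by these compounds alone, the comparison with the plain phenyl ring is more informative: adding a nitro group to that ring gives a 2.7-fold lower number from compound 1 to compound 4 (0.43 log units; beyond the scatter), the first step in this small set to clear the scatter, though only modestly. This position can therefore carry a group containing nitrogen and oxygen without the number rising, but no measurement here explains the shift from compound 1 to compound 4.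

The compounds shown do not separate the effect of the nitro group from the effect of where it sits, since compound 3 and compound 4 differ in both the substituent and its location on the ring. They also leave open how this position would respond to an amine or a carboxylic acid on the phenyl ring, or to a longer chain in place of that ring.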